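A few compounds are considered here, and "the series" means these few. Any claim that something is new, unique, unknown or untested is made for them only; others in the source may bear on it.

Measured in a functional assay on HeLa cells (Homo sapiens) for cytotoxicity, read by ELISA, with a stated time of 2 days; a lower number here means a stronger inhibitor, a higher number a weaker inhibitor:
Compound 1 `Oc1cccc(-c2cc(-c3ccccc3)cc(-c3ccccc3)n2)c1`: 16100 nM
Compound 2 `Oc1ccc(-c2cc(-c3ccccc3)cc(-c3ccccc3)n2)cc1`: 1700 nM

Among the compounds with values here, of the two numbers so far, compound 2 has the lower, at 1700 nM, and compound 1 is its only neighbour. The next structure, compound 3 `Oc1ccc(-c2cc(-c3ccccc3)cc(-c3cccnc3)n2)cc1`, keeps the 4-hydroxyphenyl group of compound 2 but has pyridin-3-yl in place of phenyl on an aromatic carbon next to the ring nitrogen: pyridin-3-yl in place of phenyl on an aromatic carbon.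

Within the data shown here, only one measured step is available, a 9.5-fold lower number from compound 1 to compound 2 (0.98 log units; beyond the scatter), and it lies beyond the scatter. That step exchanges 3-hydroxyphenyl for 4-hydroxyphenyl, elsewhere on the shared core, so it bears on the new change only indirectly. It shows that one substituent change can move the number in this assay, but it gives neither the size nor the direction for this exchange. Among the measured compounds shown here, no measured pair tests phenyl against pyridin-3-yl. A small shift towards a weaker number is therefore expected, probably not beyond the scatter, though with wide uncertainty. The expected change is a 1.5-fold higher number from compound 2 to compound 3 (0.17 log units; within the scatter). Compound 3 is estimated at 2500 nM, with an expected range of 700 nM to 9000 nM.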

Compound 3, half-maximal inhibitory concentration: 13600 nM
Compound 3: middle estimate off by 5.4-fold (0.74 log units), on the low side; measured number outside the range, above it.
By their numbers in this assay, from the lowest: compound 2; then compounds 3 and 1 (each within the scatter of the next).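

In this assay, the exchange of phenyl for pyridin-3-yl next to the ring nitrogen gives an 8.0-fold higher number from compound 2 to compound 3 (0.90 log units; beyond the scatter), so this position is sensitive to a change that leaves the count of 6 heavy atoms the same and replaces one ring carbon with nitrogen, adding 1 hydrogen-bond acceptor. Together with a 9.5-fold lower number from compound 1 to compound 2 (0.98 log units; beyond the scatter), this shows that compound 2 has the lower number in both single-place comparisons, one at the hydroxyphenyl group and one at this ring, and that the number responds to a change at either place. No measured evidence accounts for the effect of the nitrogen on this step.

The compounds shown leave open whether the placement of the ring nitrogen matters, as pyridin-2-yl or pyridin-4-yl at the same carbon would test, and whether any other group there, such as a 4-aminophenyl or a 4-methoxyphenyl group, would keep the number of compound 2. They also leave open whether the same exchange at the remaining phenyl group would give a similar step.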